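The source may hold more compounds than are shown below. What is called first, only, known or untested is meant among the compounds shown, and "the series" means these compounds.

Measured compounds:
compound 1, `COc1cc(C)cc(-c2c(-c3ccnc(-c4ccc(N(C)C)cc4)c3)cnn2CC#N)c1`, 72%
compound 2, `COc1cc(C)cc(-c2nn(CC#N)cc2-c2ccnc(-c3ccc(N(C)C)cc3)c2)c1`, 116%
compound 3, `COc1cc(C)cc(-c2nn(CC#N)cc2-c2ccc(-c3cccc(C(C)=O)c3)nc2)c1`, 100%

Three compounds sharing a common core were examined in a functional assay on COLO 205 cells (Homo sapiens) for cytotoxicity, read by sulforhodamine B assay, with a stated time of 48 h, tested at 0.01 uM; on this read-out lower numbers stand for a stronger effect and higher numbers for a weaker effect at the one concentration tested. Compound 1 stands lowest of the three numbers, with compound 3 giving a reading beyond the scatter higher than compound 1, and compound 2 giving one still further above it. Compound 1 is thus the one with the strongest effect among these three in this assay. Going by the values given here, no single-point step between two measured compounds is available, so the pairs can only be compared by their values as they stand.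

The next compound is compound 4, `COc1cc(C)cc(-c2c(-c3ccnc(-c4ccc(C(C)=O)cc4)c3)cnn2CC#N)c1`, not yet measured in this assay. It differs from compound 1 in one place: acetyl in place of dimethylamino on an aromatic carbon. The 4-(dimethylamino)phenyl becomes a 4-acetylphenyl, para to a large group.

Because compound 3, which also carries an acetyl on its outer ring, gives 100%, the expectation is a weaker effect for compound 4 than compound 1, with an estimated step of a number 23 percentage points higher from compound 1 to compound 4 (beyond the scatter) in this assay. Compound 4 is therefore estimated at 95%, within a range from 72% to 118%.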

Compound 4, a percentage reported as activity, at one concentration (the size of the read-out at that concentration, not a potency): 102%
The estimate for compound 4 lay 7 percentage points below the measured number; low and high end bracket the measured number.
By their numbers in this assay, from the lowest: compound 1; then compounds 3 and 4 (each within the scatter of the next); then compound 2.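

In this assay, going by these compounds alone, the change from 4-(dimethylamino)phenyl to 4-acetylphenyl gives a number 30 percentage points higher from compound 1 to compound 4 (beyond the scatter) and is the first direct reading of a single change in this set. The reading at this position therefore depends on the group it carries, with dimethylamino giving the stronger effect of this pair, even though the two groups have the same number of heavy atoms and hydrogen-bond acceptors. Nothing available explains the difference between them.

From the compounds shown here alone, whether a primary amine, a morpholine or a methoxy group at this place would give a reading like that of dimethylamino or like that of acetyl remains open. With only one concentration, the compounds also leave open how this change would affect potency across a full concentration range.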